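A Spiro Lactam in Place of an Open Amide

The compounds below may be only part of what the source reports. "The series", "measured", "known", "first", "only" and "open" are said of these compounds alone.

Of the compounds shown here, three share a core and have been measured in a physicochemical assay for lipophilicity, using the shake flask method, in phosphate buffer, measured as octanol-water partition, with a stated time of 30 min, at pH 7.4; on this read-out higher numbers stand for higher lipophilicity and lower numbers for lower lipophilicity. Compound 1 `Cc1ncccc1-c1cnc(NCc2c(F)ccc3c2CCO3)c2nn(CC#N)c(=O)n12` gives 2.2. Compound 2 `COCCC(=O)Nc1cnc(NCc2c(F)ccc3c2CCO3)n2cnnc12` gives 1.4, the lowest of the three numbers, with compound 3 `CN(C)Cc1ccc(C(=O)Nc2cnc(NCc3c(F)ccc4c3CCO4)n3cnnc23)cc1` giving 1.8 as its nearest neighbour and compound 1 standing furthest from it. Among the compounds with values here, the only step between compounds that differ in one place is a number 0.40 log units higher from compound 2 to compound 3 (beyond the scatter), where 4-((dimethylamino)methyl)phenyl replaces 2-methoxyethyl on a carbonyl carbon.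

Compound 4 `O=C1CC2(CC2)CN1c1cnc(NCc2c(F)ccc3c2CCO3)n2cnnc12` has not yet been measured. It differs from compound 2 in this way: a group of 8 heavy atoms (6 carbon, 1 nitrogen, 1 oxygen; one three-membered non-aromatic ring of carbon only, one five-membered non-aromatic ring with 1 hetero atom) in place of a group of 7 heavy atoms (4 carbon, 1 nitrogen, 2 oxygen; no ring), on an aromatic carbon. The step from compound 2 to compound 3 bears only loosely on this change, since it kept the ((2-methoxyethyl)carbonyl)amino attachment and changed its far end, yet it shows that replacing the 2-methoxyethyl piece of compound 2 raised the number by a modest amount. Loss of the hydrogen-bond donor and one acceptor, with one more carbon, leads to an expected step of a number 0.50 log units higher from compound 2 to compound 4 (beyond the scatter). Compound 4 is therefore estimated at 1.9, with a range from 1.4 to 2.4.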

Compound 4, distribution coefficient: 1.9
Compound 4: the middle estimate sits on the measured number at the digits printed; the measured number falls inside the stated range.
By their numbers in this assay, from the lowest: compound 2; then compounds 3, 4 and 1 (each within the scatter of the next, the first and the last beyond it).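

In this assay, the group of 8 heavy atoms in place of ((2-methoxyethyl)carbonyl)amino gives a number 0.50 log units higher from compound 2 to compound 4 (beyond the scatter), and this is the first step shown in which the attachment to this aromatic carbon itself changes, not just the far end of the amide. The group that enters carries 0 hydrogen-bond donors and 1 hydrogen-bond acceptor and is closed into two rings, while the group that leaves carries 1 hydrogen-bond donor and 2 hydrogen-bond acceptors and has no ring. Nothing available ties the step to any one of these differences.

The compounds shown do not separate the three-membered carbon ring from the five-membered lactam ring, so a plain pyrrolidinone at this carbon would be informative. An open amide with a methyl group in place of the amide hydrogen also remains an open comparison.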